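Capping a Hydroxy Group with Methyl: Compound 4 Expected

A few compounds are considered here, and "the series" means these few. Any claim that something is new, unique, unknown or untested is made for them only; others in the source may bear on it.

In a functional assay on the whole organism for inhibition, with Brassica napus as the target, with a stated time of 72 h, tested at 100 mg/L (a lower number here means less inhibition of growth, a higher number more inhibition of growth at the concentration tested), compound 1 `Cc1cc(O)nc(NC(=S)NC(=O)c2c(-c3ccc(Cl)cc3Cl)noc2C)n1` gives 52.3%.
In this assay compound 2 `COc1cc(Cl)nc2n/c(=N/C(=O)c3c(-c4ccc(Cl)cc4Cl)noc3C)sn12` gives 70.8%.
In this assay compound 3 `COc1cc(SC)nc2n/c(=N/C(=O)c3c(-c4ccc(Cl)cc4Cl)noc3C)sn12` gives 75.8%.

Compound 1 has the lowest of the three numbers; compound 2 lies higher beyond the scatter, and compound 3 further still. Compound 4 `COc1cc(C)nc(NC(=S)NC(=O)c2c(-c3ccc(Cl)cc3Cl)noc2C)n1` differs from compound 1 by methyl in place of hydrogen on an oxygen on an aromatic ring, that is hydroxy becomes methoxy. Among the measured compounds shown here, the only measured step, a number 5 percentage points higher from compound 2 to compound 3 (within the scatter), concerns another group on another core, so no measured step bears directly on this change. Compounds 2 and 3 do carry a methoxy group and sit higher than compound 1, yet their core differs as well, so this is a hint only. A small upward step is therefore expected, a number 5.7 percentage points higher from compound 1 to compound 4 (within the scatter). Compound 4 is estimated at 58%, between 40% and 76%.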

Compound 4, percent growth inhibition at one concentration: 69.3%
Estimate against measurement, compound 4: 11.3 percentage points below, within the range that was stated.
By their numbers in this assay, from the lowest: compound 1; then compounds 4, 2 and 3 (each within the scatter of the next).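

Replacing hydroxy with methoxy on the 4-hydroxy-6-methylpyrimidin-2-yl group raises growth inhibition in this assay, with a number 17 percentage points higher from compound 1 to compound 4 (beyond the scatter). This is the only step shown at this position, and it shows that the hydrogen on this oxygen is not required for inhibition at the concentration tested. No available evidence explains the rise. On these data alone, it remains open whether a longer chain such as ethoxy on the same oxygen would raise inhibition further. An amine in place of the hydroxy is also untested among the compounds shown here.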